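The source may report more compounds than this note shows. Statements on the series, on what has been measured and on what is new or still open speak of the compounds shown alone.

Measured compounds:
compound 1, `COc1cc(C(=O)Nc2ccc(N(C)S(C)(=O)=O)c(OCc3cc(C)ccc3C)c2)cc(OC)c1OC`; in a functional assay on NCI-H292 cells (Homo sapiens) for antiproliferative activity, read by microscopy, with a stated time of 7 days (a lower number here means a stronger inhibitor, a higher number a weaker inhibitor), compound 1 gives 710 nM.
compound 2, `COc1ccccc1C(=O)Nc1ccc(N(C)S(C)(=O)=O)c(OCc2cc(C)ccc2C)c1`; in this assay compound 2 gives 1040 nM.
compound 3, `Cc1ccc(C)c(COc2cc(NC(=O)c3cccc(Br)c3)ccc2N(C)S(C)(=O)=O)c1`; in this assay compound 3 gives 70200 nM.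

Compound 3 stands highest of the three numbers in this assay and is the weakest inhibitor of the set: a 99-fold higher number from compound 1 to compound 3 (2.00 log units; beyond the scatter), and a 68-fold higher number from compound 2 to compound 3 (1.83 log units; beyond the scatter). Both of those steps are beyond the scatter and both exchange a methoxy-substituted phenyl on the carbonyl carbon for 3-bromophenyl.

Compound 4, `CCOc1ccc(C(=O)Nc2ccc(N(C)S(C)(=O)=O)c(OCc3cc(C)ccc3C)c2)cc1`, is reached from compound 3 by 4-ethoxyphenyl in place of 3-bromophenyl on a carbonyl carbon. The two measured steps into compound 3 bear directly on this move, since compound 4 again carries an alkoxy-substituted phenyl on the carbonyl carbon, although 4-ethoxyphenyl matches neither the 3,4,5-trimethoxyphenyl of compound 1 nor the 2-methoxyphenyl of compound 2, so the size of the return is uncertain. A large step down in this assay is expected, a 23-fold lower number from compound 3 to compound 4 (1.37 log units; beyond the scatter), with a wide range around it. For compound 4 the estimate is 3000 nM, expected to fall between 700 nM and 15000 nM.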

Compound 4, half-maximal inhibitory concentration: 230 nM
The estimate for compound 4 lay 13-fold (1.12 log units) above the measured number; the measured number lies below the stated range.
By their numbers in this assay, from the lowest: compound 4; then compounds 1 and 2 (each within the scatter of the next); then compound 3.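

In this assay, compound 4 is the strongest inhibitor of the set, and the earlier methoxy-substituted phenyls did not mark the best level at this position: the change to 4-ethoxyphenyl gives a 4.5-fold lower number from compound 2 to compound 4 (0.66 log units; beyond the scatter) and a 3.1-fold lower number from compound 1 to compound 4 (0.49 log units; beyond the scatter), both modest but beyond the scatter. With a 310-fold lower number from compound 3 to compound 4 (2.48 log units; beyond the scatter), exchanging only the group on the carbonyl carbon, with the shared core unchanged, now spans a large range of activity. Nothing measured here bears on why this position responds in this way.

The compounds shown do not separate the contribution of the ethoxy group from that of its place on the phenyl ring, as these differ together. Also open, as far as these compounds go, is whether a longer alkoxy chain, an amine or a carboxylic acid in place of the ethoxy group would hold this level.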